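Bromo to nitro swap on the aryl of a small series

The source may report more compounds than this note shows. Statements on the series, on what has been measured and on what is new or still open speak of the compounds shown alone.

Measured in a functional assay on MCF7 cells (Homo sapiens) for inhibition, read by sulforhodamine B assay, with a stated time of 72 h (a higher number here means a weaker inhibitor, a lower number a stronger inhibitor), so far:
- compound 1 `COc1ccc2cc(C(C)c3nnc4n3N=C(c3ccc([N+](=O)[O-])cc3)CS4)ccc2c1` gives 18800 nM
- compound 2 `COc1ccc2cc(C(C)c3nnc4n3N=C(c3ccc(Br)cc3)CS4)ccc2c1` gives 11500 nM
- compound 3 `CC(C)Cc1ccc(C(C)c2nnc3n2N=C(c2ccc(Br)cc2)CS3)cc1` gives 9400 nM

Compound 2 and compound 1 share a core and differ by nitro in place of bromo on an aromatic carbon; in this assay this gave a 1.6-fold higher number from compound 2 to compound 1 (0.21 log units; within the scatter), so the two values of compound 2 and compound 1 are not separable here. Compound 3 carries a different core from compound 2, and the difference between the two cores is not broken down here; their values in this assay lie within the scatter of each other, as does the pair of compound 3 and compound 1.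

Compound 4 `CC(C)Cc1ccc(C(C)c2nnc3n2N=C(c2ccc([N+](=O)[O-])cc2)CS3)cc1` is not yet measured. It differs from compound 3 by nitro in place of bromo on an aromatic carbon, the same change as from compound 2 to compound 1, made on the core of compound 3 and at the same place. Among the measured compounds shown here, the step in this assay is expected to be of similar size, because a 1.6-fold higher number from compound 2 to compound 1 (0.21 log units; within the scatter) is the only prior instance of this change, giving an expected 1.6-fold higher number from compound 3 to compound 4 (0.20 log units; within the scatter). The estimate for compound 4 in this assay is 15000 nM, with the range set wide given the scatter.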

Compound 4, half-maximal inhibitory concentration: "not active" (no number reported)
No number was reported for compound 4; there is nothing to compare the estimate with.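

Among the compounds shown here, compound 4 is reported as "not active" in this assay with no number, so no step from compound 3 to compound 4 can be read. The compounds shown leave open whether 4-bromophenyl to 4-nitrophenyl on the core of compound 3 matches a 1.6-fold higher number from compound 2 to compound 1 (0.21 log units; within the scatter) on the other core. No other data shown bear on this result.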